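Efficacy of arylacetamides at the free fatty acid receptor

This account rests on a few compounds, and the source may have more. Where it says the series, first, only, none or still open, it means among the compounds named here.

Measured so far:
compound 1 `CC(C)[C@H](C(=O)Nc1ccon1)c1ccc(Cl)cc1`: 90%
compound 2 `CC(C)C(C(=O)Nc1nc2ccccc2s1)c1ccc(Cl)cc1`: 91%
compound 3 `CC(C)(C)[C@H](C(=O)Nc1ncc(F)s1)c1ccc(Cl)cc1`: 92%

In a functional assay on CHO cells for agonist activity at Free fatty acid receptor 2 (Homo sapiens), read by cAMP accumulation (on this read-out lower numbers stand for smaller maximal responses and higher numbers for larger maximal responses), compound 1 gives 90%, compound 2 gives 91% and compound 3 gives 92%. Compound 3 holds the highest of the three numbers, yet compound 2 and compound 1 both lie within the scatter of it, so the three cannot be ordered; all reach a comparably full maximal response.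

Compound 4 `CC(C)(C)[C@H](C(=O)Nc1ncc(Cc2ccc(Cl)cc2)s1)c1ccc(Cl)cc1` differs from compound 3 by 4-chlorobenzyl in place of fluoro on an aromatic carbon. Within the data shown here, no measured pair isolates this change, so its step in this assay is unknown. Since every measured compound sits near the same plateau, the step from compound 3 to compound 4 is expected to be a number 4 percentage points lower from compound 3 to compound 4 (within the scatter), none beyond the scatter. Compound 4 is therefore expected to give 88%, estimated between 70% and 102%.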

Compound 4, largest response reached (reported as efficacy), in percent of the reference or control that the assay uses: 100%
The estimate for compound 4 lay 12 percentage points below the measured number; the measured number falls inside the stated range.
By their numbers in this assay, from the lowest: compounds 1, 2, 3 and 4 (each within the scatter of the next).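

In this assay, 4-chlorobenzyl in place of fluoro on the aromatic carbon next to the ring sulfur gives a number 8 percentage points higher from compound 3 to compound 4 (within the scatter). This position therefore carries a far larger group, with an extra six-membered aromatic ring, and the maximal response shows no change beyond the scatter. Nothing available explains why the response holds with this group. Still open, as far as these compounds go, is whether an amine or a carboxylic acid at this position would also keep the maximal response. A single pair also cannot show whether the same tolerance holds with the other amide groups in the series.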